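A few compounds are considered here, and "the series" means these few. Any claim that something is new, unique, unknown or untested is made for them only; others in the source may bear on it.

Compound 2 `COc1cccc(Cn2nnc(-c3cc([N+](=O)[O-])cc([N+](=O)[O-])c3)n2)c1` gives > 100000 nM in an ADME assay on CHO-K1 cells (Cricetulus griseus) for cytotoxicity, read by MTT assay, with a stated time of 24 h (a lower number here means a stronger inhibitor, a higher number a weaker inhibitor), and that value is a limit of the assay rather than a number. Compound 1 `O=[N+]([O-])c1cc(-c2nnn(Cc3cccc(Cl)c3)n2)cc([N+](=O)[O-])c1` gives 27000 nM in this assay. Between them stands an at least 3.7-fold higher number from compound 1 to compound 2 (0.56 log units; beyond the scatter), a step bounded only by the limit of > 100000 nM in this assay, at which 1 of the 2 values shown sits. Compound 3 `O=[N+]([O-])c1cc(-c2nnn(Cc3ccc(Cl)c(Cl)c3)n2)cc([N+](=O)[O-])c1` differs from compound 2 by 3,4-dichlorophenyl in place of 3-methoxyphenyl on a saturated chain carbon bound to an aromatic nitrogen. A step of an at least 5.0-fold lower number from compound 2 to compound 3 (0.69 log units; beyond the scatter) is expected because the change undoes an at least 3.7-fold higher number from compound 1 to compound 2 (0.56 log units; beyond the scatter) and adds a second chloro on the same ring. Compound 3 is therefore estimated at 20000 nM, within a range from 7000 nM to 60000 nM.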

Compound 3, half-maximal inhibitory concentration: 37000 nM
The estimate for compound 3 lay 1.9-fold (0.27 log units) below the measured number, within the range that was stated.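

In this assay, a second chloro on the ring gives no change beyond the scatter: a 1.4-fold higher number from compound 1 to compound 3 (0.14 log units; within the scatter). The 3,4-dichlorophenyl ring therefore sits with the single chloro ring, and apart from 3-methoxyphenyl: an at least 2.7-fold lower number from compound 2 to compound 3 (0.43 log units; beyond the scatter). That step has no exact size, since the value of compound 2 is a limit and not a number: the limit of > 100000 nM in this assay, at which 1 of the 3 values shown sits.

Still open, as far as these compounds go, is where a ring with neither chloro nor methoxy would fall in this assay. So is what an amine or a carboxylic acid at this ring would do.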